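Amide change from compound 2 to compound 3

This account rests on a few compounds, and the source may have more. Where it says the series, first, only, none or still open, it means among the compounds named here.

Compound 2 `CCCNC(=O)c1c(NC(=O)NS(=O)(=O)c2ccccc2)sc2c1CCCCC2` stands only at a limit: in a functional assay on MCF7 cells (Homo sapiens) for inhibition, with a stated time of 48 h (a lower number here means a stronger inhibitor of growth, a higher number a weaker inhibitor of growth), compound 2 gives > 100000 nM, a limit of the assay rather than a number. Compound 1 `O=C(Nc1sc2c(c1C(=O)NNc1ccccc1)CCCCC2)NS(=O)(=O)c1ccccc1` likewise gives a limit, > 100000 nM in this assay. Among the compounds with values here, the one measured step, a step that the two limits leave unreadable from compound 1 to compound 2, carries no readable size since (the limit of > 100000 nM in this assay, at which 2 of the 2 values shown sit). Compound 3 `O=C(Nc1sc2c(c1C(=O)N1CCN(c3ccccc3)CC1)CCCCC2)NS(=O)(=O)c1ccccc1` differs from compound 2 by 4-phenylpiperazin-1-yl in place of propylamino on a carbonyl carbon. With no readable measured step to rest on, the expected step is a step that the limit leaves unreadable from compound 2 to compound 3, most probably ending at another limit. Compound 3 is estimated at 150000 nM, range 30000 nM to 500000 nM.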

Compound 3, concentration for 50% growth inhibition: > 100000 nM
Compound 3 ended at the assay's limit; the forecaster's own chance of this, stated with the estimate: 75%; the middle value lies beyond the limit too.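

Compound 3, like compound 1 and compound 2, stands only at a limit, so no new step can be read: the limit of > 100000 nM in this assay, at which 3 of the 3 values shown sit.

The compounds shown leave open whether any amide on the shared core gives a measurable value in this assay.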